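Capping the hydroxy group of compound 3

The source may report more compounds than this note shows. Statements on the series, on what has been measured and on what is new or still open speak of the compounds shown alone.

Values in a functional assay on LNCaP cells (Homo sapiens) for antiproliferative activity (on this read-out lower numbers stand for stronger inhibition and higher numbers for weaker inhibition), for three compounds
Compound 1 `Cn1ncc(Cl)c1-c1cc(C(=O)N[C@@H]2CN[C@H](CC(=O)NCC(O)CO)C[C@H]2c2ccc(Cl)c(Cl)c2)oc1Cl` gives 660 nM
Compound 2 `Cn1ncc(Cl)c1-c1cc(C(=O)N[C@@H]2CN[C@H](CC(=O)NC3CC3)C[C@H]2c2ccc(Cl)c(Cl)c2)oc1Cl` gives 190 nM
Compound 3 `Cn1ncc(Cl)c1-c1cc(C(=O)N[C@@H]2CN[C@H](CCO)C[C@H]2c2ccc(Cl)c(Cl)c2)oc1Cl` gives 160 nM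

Compound 3 stands at the low end of these numbers. It is level with one neighbour (a 1.2-fold lower number from compound 2 to compound 3 (0.07 log units; within the scatter)) and clear of the other (a 4.1-fold lower number from compound 1 to compound 3 (0.62 log units; beyond the scatter)).

Compound 4 `COCC[C@@H]1C[C@@H](c2ccc(Cl)c(Cl)c2)[C@H](NC(=O)c2cc(-c3c(Cl)cnn3C)c(Cl)o2)CN1` differs by a single change (methyl in place of hydrogen on an oxygen on a saturated carbon), methyl in place of hydrogen on an oxygen on a saturated carbon, so 2-hydroxyethyl becomes 2-methoxyethyl. Going by the values given here, no measured step makes this change. The closest guide is that larger swaps at the same chain moved the number little in one case (a 1.2-fold lower number from compound 2 to compound 3 (0.07 log units; within the scatter)) and only modestly in another (a 4.1-fold lower number from compound 1 to compound 3 (0.62 log units; beyond the scatter)). The expected step is therefore none beyond the scatter (a 1.1-fold higher number from compound 3 to compound 4 (0.03 log units; within the scatter)). Compound 4 is estimated at (170 nM), with an expected range from (70 nM) to (400 nM).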

Compound 4, half-maximal inhibitory concentration: 250 nM
For compound 4 the middle estimate is 1.5-fold (0.17 log units) below the measured one; the measured number falls inside the stated range.
By their numbers in this assay, from the lowest: compounds 3, 2 and 4 (each within the scatter of the next); then compound 1.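

In this assay the hydrogen on the hydroxy oxygen of the 2-hydroxyethyl chain can give way to methyl without a change beyond the scatter (a 1.6-fold higher number from compound 3 to compound 4 (0.19 log units; within the scatter)). The 2-methoxyethyl chain also stays level with the cyclopropyl amide chain (a 1.3-fold higher number from compound 2 to compound 4 (0.12 log units; within the scatter)), and it remains clear of the 2,3-dihydroxypropyl amide chain (a 2.6-fold lower number from compound 1 to compound 4 (0.42 log units; beyond the scatter)). Nothing available explains these numbers. Still open, going by these compounds, is how an amine or a carboxylic acid at the end of this chain, or a longer chain carrying the methoxy group, would read here.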